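The source may hold more compounds than are shown below. What is called first, only, known or untested is meant among the compounds shown, and "the series" means these compounds.

Measured so far in a functional assay on MKN-74 cells (Homo sapiens) for antiproliferative activity, with a stated time of 24 h; a higher number here means a weaker inhibitor, a lower number a stronger inhibitor:
- compound 1, `NC(=O)c1c(NC(=O)c2ccccc2Cl)sc2c1CCN(Cc1c(Cl)cccc1Cl)C2`, gives 4740 nM
- compound 2, `NC(=O)c1c(NC(=O)c2ccccc2Cl)sc2c1CCN(C(=S)Nc1ccccc1F)C2`, gives 12600 nM

Compound 2 stands at the highest of the two numbers, so it is the weaker inhibitor of the pair; compound 1 lies below it by a 2.7-fold higher number from compound 1 to compound 2 (0.42 log units; beyond the scatter), a gap beyond the usual scatter of this assay. Compound 3, `NC(=O)c1c(NC(=O)c2ccccc2Cl)sc2c1CCN(C(=O)Nc1c(Cl)cccc1Cl)C2`, is the next structure in line. Compared with compound 2, the change is this: a group of 11 heavy atoms (7 carbon, 1 nitrogen, 1 oxygen, 2 chlorine; one six-membered aromatic ring of carbon only) in place of a group of 10 heavy atoms (7 carbon, 1 nitrogen, 1 fluorine, 1 sulfur; one six-membered aromatic ring of carbon only), on an amine nitrogen in a ring. In plain terms, the aromatic ring that carries one fluorine gives way to one that carries two chlorines, and the sulfur of the link is exchanged for an oxygen, while the link to the ring nitrogen keeps its shape.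

Within the data shown here, only one measured step bears on this. In a 2.7-fold higher number from compound 1 to compound 2 (0.42 log units; beyond the scatter) the two-chlorine ring was lost and a fluorine-bearing ring with a sulfur link came in, and the number rose modestly. Compound 3 brings the two-chlorine ring back, though through a different link, so a modest fall in this assay is expected, of about a 1.8-fold lower number from compound 2 to compound 3 (0.26 log units; within the scatter), with the link change left as an unknown. The estimate for compound 3 is therefore 7000 nM, within a range from 2500 nM to 20000 nM.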

Compound 3, half-maximal inhibitory concentration: 24400 nM
The estimate for compound 3 lay 3.5-fold (0.54 log units) below the measured number; the whole stated range lies below it.
By their numbers in this assay, from the lowest: compound 1; then compounds 2 and 3 (each within the scatter of the next).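

In this assay, keeping the two-chlorine aromatic ring on the amine nitrogen in the ring does not by itself hold the level of compound 1: replacing 2,6-dichlorobenzyl with (2,6-dichlorophenyl)carbamoyl gives a 5.1-fold higher number from compound 1 to compound 3 (0.71 log units; beyond the scatter) as a modest step, so the link between ring and nitrogen counts among these compounds. The other step, a 1.9-fold higher number from compound 2 to compound 3 (0.29 log units; within the scatter), changes both the ring substituents and the sulfur-for-oxygen link at once, and it shows no separable effect of either change, so the two groups with a nitrogen in the link cannot be told apart in this assay, while both give higher numbers than compound 1. Nothing available explains why the link change matters here.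

The compounds shown leave open how the oxygen and sulfur links compare on an identical aromatic ring, and how the fluorine and chlorine patterns compare on an identical link. They also leave open whether the aromatic ring is needed at all, for instance whether a plain ethyl or a longer alkyl chain on the same nitrogen would keep the number of compound 1.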